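The source may hold more compounds than are shown below. What is called first, only, known or untested is meant among the compounds shown, and "the series" means these compounds.

- Compound 1 `O=C(CCCCCCNC(=O)C(O)(O)C(F)(F)F)Nc1ccccc1Br`: 14500 nM
- Compound 2 `O=C(CCCCCCNC(=O)C(O)(O)C(F)(F)F)Nc1ccncc1`: 6670 nM

Among the compounds with values here, in a functional assay on HCT-116 cells (Homo sapiens) for inhibition, read by colorimetric assay, with a stated time of 3 days (on this read-out higher numbers stand for weaker inhibition and lower numbers for stronger inhibition), compound 2 gives 6670 nM, the lower of the two numbers so far. Compound 3 `COc1ccc(NC(=O)CCCCCCNC(=O)C(O)(O)C(F)(F)F)cc1` is still unmeasured and differs from compound 2 by 4-methoxyphenyl in place of pyridin-4-yl on an amide-type nitrogen. Within the data shown here, the only measured step that bears on this is modest: a 2.2-fold lower number from compound 1 to compound 2 (0.34 log units; beyond the scatter), with pyridin-4-yl replacing 2-bromophenyl. Here pyridin-4-yl leaves instead, so a modest move the opposite way is expected, although a different group enters and one step is thin evidence. The expected step is a 1.5-fold higher number from compound 2 to compound 3 (0.18 log units; within the scatter). Compound 3 is estimated at 10000 nM, with an expected range of 4000 nM to 25000 nM.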

Compound 3, half-maximal inhibitory concentration: 4520 nM
Estimate against measurement, compound 3: 2.2-fold (0.34 log units) above; the measured number falls inside the stated range.
By their numbers in this assay, from the lowest: compounds 3 and 2 (each within the scatter of the next); then compound 1.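

In this assay, putting 4-methoxyphenyl in place of pyridin-4-yl on the amide-type nitrogen gives a 1.5-fold lower number from compound 2 to compound 3 (0.17 log units; within the scatter) and so does not separate these two groups. Replacing 2-bromophenyl with 4-methoxyphenyl gives a 3.2-fold lower number from compound 1 to compound 3 (0.51 log units; beyond the scatter) and shows that a ring of carbon only can also stand clear of compound 1, so the ring nitrogen of pyridin-4-yl is not required for that. Nothing available explains these differences.

From the compounds shown here alone, whether a plain phenyl ring or an aminophenyl group on this nitrogen would fall with compound 2 and compound 3 remains open. So does the effect of a shorter or longer chain.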